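Aryl isomer swap on the cyclobutyl sulfonamide

The source may hold more compounds than are shown below. What is called first, only, known or untested is meant among the compounds shown, and "the series" means these compounds.

Values so far in a physicochemical assay for lipophilicity, at pH 7.4 (on this read-out lower numbers stand for lower lipophilicity and higher numbers for higher lipophilicity), are these
- compound 1 `CCc1ccc(N(Cc2ccccc2)S(=O)(=O)c2ccc3c(c2)C(=O)CC(C2CCOCC2)O3)cc1` gives 4.84
- compound 2 `Cc1ccc(NS(=O)(=O)c2ccc3c(c2)C(=O)CC(C2CCOCC2)O3)c(C)c1` gives 2.75
- compound 3 `Cc1ccc(N(C2CCC2)S(=O)(=O)c2ccc3c(c2)C(=O)CC(C2CCOCC2)O3)c(C)c1` gives 3.86

Compound 3 stands second highest of the three, under compound 1 and over compound 2. The move to compound 4 `CCc1ccc(N(C2CCC2)S(=O)(=O)c2ccc3c(c2)C(=O)CC(C2CCOCC2)O3)cc1` puts 4-ethylphenyl in place of 2,4-dimethylphenyl on a sulfonamide nitrogen and leaves the cyclobutyl group unchanged. Within the data shown here, the one measured step of a number 1.11 log units higher from compound 2 to compound 3 (beyond the scatter) was large, yet it is cyclobutyl in place of hydrogen, a change not repeated here. Among the measured compounds shown here, no measured step covers this aryl exchange, so it bears only weakly. The expected step of a number 0.09 log units higher from compound 3 to compound 4 (within the scatter) is none beyond the scatter. Compound 4 is estimated at 3.95 with an expected range from 3.55 to 4.35 for now.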

Compound 4, distribution coefficient: 3.78
Estimate against measurement, compound 4: 0.17 log units above; the range from low to high includes it.
By their numbers in this assay, from the lowest: compound 2; then compounds 4 and 3 (each within the scatter of the next); then compound 1.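

In this assay, 4-ethylphenyl in place of 2,4-dimethylphenyl on the sulfonamide nitrogen gives a number 0.08 log units lower from compound 3 to compound 4 (within the scatter), so with cyclobutyl held, this aryl exchange leaves no readable difference. With 4-ethylphenyl held, the other substituent on that nitrogen does matter: cyclobutyl in place of benzyl gives a number 1.06 log units lower from compound 1 to compound 4 (beyond the scatter). No measurement on hand accounts for either step.

Open, going by these compounds, is whether an aryl group carrying an amine or a carboxylic acid would also stay within the scatter of compound 3. Also open, on these data alone, is where a longer straight chain on the sulfonamide nitrogen would fall relative to cyclobutyl and benzyl.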